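Working notes: from compound 2 to compound 3

A few compounds are considered here, and "the series" means these few. Any claim that something is new, unique, unknown or untested is made for them only; others in the source may bear on it.

Compound 1 `C/C(=C\CC/C(C)=C/CC[C@@H]1[C@@]2(C)CCC(=O)C(C)(C)[C@H]2CC[C@@]1(C)O)CC/C=C(\C)C(=O)OCc1cn(-c2ccccc2Br)nn1`: > 150000 nM (a limit)
Compound 2 `C/C(=C\CC/C(C)=C/CC[C@@H]1[C@@]2(C)CCC(=O)C(C)(C)[C@H]2CC[C@@]1(C)O)CC/C=C(\C)C(=O)OCc1cn(-c2ccc(Cl)cc2)nn1`: > 150000 nM (a limit)

Both readings come from a functional assay on A549 cells (Homo sapiens) for antiproliferative activity, read by MTT assay, with a stated time of 48 h; on this read-out lower numbers stand for stronger inhibition and higher numbers for weaker inhibition. Compound 2 stands at the limit of > 150000 nM in this assay, at which 2 of the 2 values shown sit, and that reading is a limit, not a number.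

Compound 3 `COc1cccc(-n2cc(COC(=O)/C(C)=C/CC/C(C)=C/CC/C(C)=C/CC[C@@H]3[C@@]4(C)CCC(=O)C(C)(C)[C@H]4CC[C@@]3(C)O)nn2)c1` carries 3-methoxyphenyl in place of 4-chlorophenyl on an aromatic nitrogen. Within the data shown here, the only measured change at this same aromatic nitrogen is a step that the two limits leave unreadable from compound 1 to compound 2, so it supplies no size to carry over. No step beyond the scatter is therefore expected in this assay, in either direction, and another reading at the limit is the likeliest outcome. The estimated step is a step that the limit leaves unreadable from compound 2 to compound 3. For compound 3 the expected value is 160000 nM, with an estimated range from 70000 nM to 350000 nM.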

Compound 3, half-maximal inhibitory concentration: > 150000 nM
Compound 3 gave a limit, no number; the forecaster's own chance of this, stated with the estimate: 75%; the middle value lies beyond the limit too.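

No step can be read among compound 1, compound 2 and compound 3, since each reading is a limit and not a number: the limit of > 150000 nM in this assay, at which 3 of the 3 values shown sit.

The compounds shown leave open whether any group on this aromatic nitrogen gives a numerical reading, and how such groups would rank.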